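A few compounds are considered here, and "the series" means these few. Any claim that something is new, unique, unknown or untested is made for them only; others in the source may bear on it.

On the shared core, three esters have been tested so far in a functional assay on A549 cells (Homo sapiens) for cytotoxicity, read by MTT assay, with a stated time of 48 h (a lower number here means a stronger inhibitor, a higher number a weaker inhibitor), and none of them gives a number. Compound 1 (`C=C1C(=O)O[C@H]2CC3=C[C@H](C/C(C)=C/[C@@H](OC(=O)c4ccc(C(F)(F)F)cc4)[C@H]12)OC3=O`) reads > 10000 nM as a limit of the assay. Compound 2 (`C=C1C(=O)O[C@H]2CC3=C[C@H](C/C(C)=C/[C@@H](OC(=O)c4ccc([N+](=O)[O-])cc4)[C@H]12)OC3=O`) reads > 10000 nM as a limit too. Compound 3 (`C=C1C(=O)O[C@H]2CC3=C[C@H](C/C(C)=C/[C@@H](OC(=O)CCCCBr)[C@H]12)OC3=O`) reads > 10000 nM as a limit as well. All three therefore sit together (the limit of > 10000 nM in this assay, at which 3 of the 3 values shown sit). Compound 4 (`C=C1C(=O)O[C@H]2CC3=C[C@H](C/C(C)=C/[C@@H](OC(=O)CCCCC)[C@H]12)OC3=O`) differs from compound 3 in one place (methyl in place of bromo on a saturated chain carbon, four bonds along the chain from a carbonyl carbon): methyl in place of bromo on a saturated chain carbon, four bonds along the chain from a carbonyl carbon. The measured steps offer no size to carry over (a step that the two limits leave unreadable from compound 1 to compound 2; a step that the two limits leave unreadable from compound 1 to compound 3; a step that the two limits leave unreadable from compound 2 to compound 3). Even the two steps that replace the whole group on the carbonyl carbon end at the same limit. Expected, then, is no change beyond the scatter in this assay and no firm direction (a step that the limit leaves unreadable from compound 3 to compound 4). Compound 4 is estimated at 15000 nM with an expected range from 6000 nM to 40000 nM and may well report only a limit.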

Compound 4, half-maximal inhibitory concentration: > 10000 nM
Compound 4 ended at the assay's limit; the forecaster's own chance of this, stated with the estimate: 80%; the middle value does not contradict the limit.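

In this assay compound 4 gives only a limit, like compounds 1, 2 and 3, so none of its steps to those three compounds can be read: the limit of > 10000 nM in this assay, at which 4 of the 4 values shown sit. The compounds shown leave open whether any ester on the shared core would give a real number in this assay.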